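Methyl to 2-hydroxyethyl on the pyrazole: notes

A few compounds are considered here, and "the series" means these few. Any claim that something is new, unique, unknown or untested is made for them only; others in the source may bear on it.

Two compounds share one core so far: compound 1 (`Cn1cc(-c2cc(Cl)c3ncc(Cc4ccc5ncccc5c4)n3c2)cn1`) and compound 2 (`Cn1cc(-c2cc(F)c3ncc(Cc4ccc5ncccc5c4)n3c2)cn1`). Going by the values given here, in a functional assay on EBC-1 cells (Homo sapiens) for antiproliferative activity, with a stated time of 72 h (a lower number here means a stronger inhibitor, a higher number a weaker inhibitor), compound 2 gives 0.27 nM and is the only compound with a number. Among the compounds with values here, for compound 1 the entry reads "not determined" (no result reported) and no measured step is therefore available. Compound 3 (`OCCn1cc(-c2cc(F)c3ncc(Cc4ccc5ncccc5c4)n3c2)cn1`) awaits testing and departs from compound 2 in one place (hydroxymethyl in place of hydrogen on a saturated chain carbon bound to an aromatic nitrogen): hydroxymethyl in place of hydrogen on a saturated chain carbon bound to an aromatic nitrogen, which reads one bond further out as methyl to 2-hydroxyethyl. Within the data shown here, with no measured step to lean on, only a small weakening in this assay is expected, perhaps none beyond the usual scatter. The expected step reads a 1.5-fold higher number from compound 2 to compound 3 (0.17 log units; within the scatter) on this estimate. For compound 3 the expected value is 0.4 nM with an estimated range (0.15 nM to 1.2 nM).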

Compound 3, half-maximal inhibitory concentration: 0.34 nM
The estimate for compound 3 lay 1.2-fold (0.07 log units) above the measured number; measured number inside the range.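

Methyl to 2-hydroxyethyl on the pyrazole brings a 1.3-fold higher number from compound 2 to compound 3 (0.10 log units; within the scatter) in this assay and gives the series its first readable step. At this place, on a saturated chain carbon bound to an aromatic nitrogen, hydroxymethyl can stand in place of hydrogen with no change that can be told from the scatter, so compound 2 and compound 3 remain level in this read-out. No measurement at hand bears on the reason for this result.

On these data alone, one step says nothing about how far the tolerance extends, and whether a longer chain, an amine or a carboxylic acid at the end of the chain would hold the same level remains open. Steps involving compound 1 cannot be read, so the exchange of fluorine for chlorine on the shared core also stays open.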